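Isopropyl for ethyl in a urea series on rice

The source may hold more compounds than are shown below. What is called first, only, known or untested is meant among the compounds shown, and "the series" means these compounds.

The measured compounds:
compound 1, `CCc1ccccc1NC(=O)N[C@H](C)c1ccccc1`, 92%
compound 2, `CCc1ccc(NC(=O)N[C@H](C)c2ccccc2)cc1`, 44%
compound 3, `CC(C)c1ccccc1NC(=O)N[C@H](C)c1ccccc1`, 17%

Three ureas were measured in an ADME assay on the whole organism with Oryza sativa as the target, tested at 10 uM; a lower number here means a stronger effect, a higher number a weaker effect of the compound at the concentration tested. Compound 1 gives 92%, the highest of the three numbers. Compound 3 differs from compound 1 in one place, (methyl in place of hydrogen on a saturated chain carbon bound to an aromatic carbon and a saturated chain carbon), and compound 3 gives 17%. That is a large step, a number 75 percentage points lower from compound 1 to compound 3 (beyond the scatter), well beyond the scatter. Compound 2 has the same atoms as compound 1 joined differently; how the two cores differ is not broken down here. In this assay compound 2 gives 44%, which stands between the other two, beyond the scatter from each.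

Compound 4, `CC(C)c1ccc(NC(=O)N[C@H](C)c2ccccc2)cc1`, is not yet measured. It relates to compound 2 as compound 3 relates to compound 1: the change is methyl in place of hydrogen on a saturated chain carbon bound to an aromatic carbon and a saturated chain carbon, the same change at the same place. Going by the values given here, only one instance of this change has been measured, so the expectation rests on that single step and on the fact that compound 2 starts lower than compound 1 did. A step of similar direction is expected, but the number cannot fall far before reaching the bottom of the scale, so the expected step is a number 34 percentage points lower from compound 2 to compound 4 (beyond the scatter). The estimate for compound 4 in this assay is 10%, with a likely range from 0% to 35%.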

Compound 4, a percentage reported as activity, at one concentration (the size of the read-out at that concentration, not a potency): 49%
Compound 4: middle estimate off by 39 percentage points, on the low side; the measured number lies above the stated range.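

In this assay, the ethyl to isopropyl change on the core of compound 2 gives a number 5 percentage points higher from compound 2 to compound 4 (within the scatter), so no effect of the change can be claimed on that core. The large step seen on the core of compound 1 therefore did not carry over to the core of compound 2, and the two steps are clearly not the same: the same change on two cores in this assay, a number 75 percentage points lower (beyond the scatter) from compound 1 to compound 3 and a number 5 percentage points higher (within the scatter) from compound 2 to compound 4, 80 percentage points apart, beyond the scatter of two such steps This shows that, for these two pairs, the outcome of the change depends on the core that carries it, but with a single pair on each core it gives no rule for any further core, and it does not say which feature of the two cores sets the steps apart.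

The compounds shown carry only ethyl and isopropyl at this place, so it remains open whether a tert-butyl group, a cyclopropyl group or a longer chain such as propyl would follow the steep step of the core of compound 1 or the flat one of the core of compound 2. On these data alone, it also remains open whether the same split between the two cores would appear with a methoxy group or a chlorine atom in place of these alkyl groups.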